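Adding a Fluoro Group to Compound 1: An Expectation

This account rests on a few compounds, and the source may have more. Where it says the series, first, only, none or still open, it means among the compounds named here.

compound 1, `O=c1c(C2N=C(c3ccccc3)SS2)coc2cc(Cl)ccc12`: 10500 nM
compound 2, `O=c1c(C(=S)Nc2ccccc2)coc2ccccc12`: 86400 nM
compound 3, `O=c1c(C(=S)Nc2ccccc2)coc2ccc(F)cc12`: a limit of the assay, > 100000 nM

In a functional assay on OVCAR-3 cells (Homo sapiens) for inhibition, read by sulforhodamine B assay, with a stated time of 48 h (on this read-out higher numbers stand for weaker inhibition and lower numbers for stronger inhibition), compound 1 gives the lowest number of the two compounds with a numerical value. How the core of compound 1 differs from the core of compound 2 is not broken down here. From compound 2 to compound 3 the change is fluoro in place of hydrogen on an aromatic carbon, and the measured step is an at least 1.1-fold higher number from compound 2 to compound 3 (0.06 log units; that floor lies within the scatter). Compound 3 sits at the limit of > 100000 nM in this assay, at which 1 of the 3 values shown sits.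

Compound 4, `O=c1c(C2N=C(c3ccccc3)SS2)coc2cc(Cl)c(F)cc12`, has not yet been measured. It differs from compound 1 by fluoro in place of hydrogen on an aromatic carbon. This is the same kind of change as from compound 2 to compound 3, but here the place is ortho to a chloro group. From compound 1 to compound 4 a step of a 1.3-fold higher number from compound 1 to compound 4 (0.12 log units; within the scatter) is expected, resting on the small step of an at least 1.1-fold higher number from compound 2 to compound 3 (0.06 log units; that floor lies within the scatter). The estimate for compound 4 is 14000 nM, expected between 5000 nM and 40000 nM.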

Compound 4, half-maximal inhibitory concentration: 61700 nM
Compound 4: the middle estimate sits 4.4-fold (0.64 log units) below what was measured; the measured number lies above the stated range.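

In this assay, fluoro in place of hydrogen on an aromatic carbon, ortho to a chloro group, gives a 5.9-fold higher number from compound 1 to compound 4 (0.77 log units; beyond the scatter), so inhibition clearly weakens on this core. Set beside the same change on the other core, the result reads: the same change on two cores in this assay, an at least 1.1-fold higher number (0.06 log units; that floor lies within the scatter) from compound 2 to compound 3 and a 5.9-fold higher number (0.77 log units; beyond the scatter) from compound 1 to compound 4; the limit leaves it open whether they differ. The value of compound 3 is a limit of the assay and not a number, so this pair does not show whether the change carries over from one core to the other with the same size: the limit of > 100000 nM in this assay, at which 1 of the 4 values shown sits.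

The compounds shown leave open whether another group at this place, such as methoxy or an amine, would weaken inhibition as fluoro does. They also leave open what fluoro does on this core without the chloro group.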